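A few compounds are considered here, and "the series" means these few. Any claim that something is new, unique, unknown or untested is made for them only; others in the source may bear on it.

Measured so far, in a physicochemical assay for lipophilicity; a higher number here means a more lipophilic compound, a lower number a more polar compound:

Compound 1, `CCOC(=O)/C=C(C)/C=C/CC(C)CCCC(C)(C)OC(C)=O`, gives 5.57.
Compound 2, `CC(=O)OC(C)(C)CCCC(C)C/C=C/C(C)=C/C(=O)OC(C)C`, gives 5.98.
Compound 3, `CCSC(=O)/C=C(C)/C=C/CC(C)CCCC(C)C`, gives 7.98.

Compound 1 and compound 2 share one core and differ in one place: methyl in place of hydrogen on a saturated chain carbon bound to an oxygen next to a carbonyl group and a saturated chain carbon. That change made the step of a number 0.41 log units higher from compound 1 to compound 2 (beyond the scatter), a modest rise that is still beyond the usual scatter. Compound 3 stands highest of the three; its core is not the core of compound 1, and the difference between the two cores is not broken down here.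

Compound 4, `CC(/C=C/CC(C)CCCC(C)C)=C\C(=O)SC(C)C`, has not yet been measured. It is made from compound 3 by the same kind of change: methyl in place of hydrogen on a saturated chain carbon bound to a saturated chain carbon and a sulfur. The two changes are alike in what leaves and what enters, but the surroundings differ. In compound 1 the carbon that receives the methyl is bound to an oxygen next to a carbonyl group and a saturated chain carbon; in compound 3 it is bound to a saturated chain carbon and a sulfur. So the change is of the same kind, not the same.

The step of a number 0.41 log units higher from compound 3 to compound 4 (beyond the scatter) is the one expected here, resting on the measured step of a number 0.41 log units higher from compound 1 to compound 2 (beyond the scatter) between compound 1 and compound 2. Compound 4 is therefore expected to give about 8.39 in this assay, most likely between 8.05 and 8.75.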

Compound 4, partition coefficient: 8.39
Beside the measured number, compound 4's estimate shows no gap at the digits printed; the measured number falls inside the stated range.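

In this assay, the step of a number 0.41 log units higher from compound 3 to compound 4 (beyond the scatter) matches in size the step of a number 0.41 log units higher from compound 1 to compound 2 (beyond the scatter), so ethylsulfanyl to isopropylsulfanyl on the core of compound 3 moved the number as far as the same kind of change did on the core of compound 1, although the carbon receiving the methyl has different surroundings in the two cases. These two pairs show that the step carried over from one core to the other here, but they do not show that it will hold on any further core or that the two surroundings will always give steps of the same size. Nothing available here bears on why the two steps match, so the agreement stands as an observation without an explanation.

The compounds shown leave open whether the step would keep its size if the chain on the sulfur were extended further, for example to a butyl or tert-butyl group. They also leave open whether it would survive on a related compound carrying an amine or a carboxylic acid, groups that do not appear in any of these four structures.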